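The source may report more compounds than this note shows. Statements on the series, on what has been measured and on what is new or still open speak of the compounds shown alone.

Compound 1 `CNC(=O)c1cc(Oc2ccc(Nc3nccc(N4CCCC4)n3)cc2)ccn1` is one of two compounds that have been examined in a functional assay on MDA-MB-231 cells (Homo sapiens) for inhibition, read by MTT assay, with a stated time of 72 h, tested at 20 uM (a higher number here means more inhibition at the concentration tested (going by the name of the read-out), a lower number less inhibition), where compound 1 gives 46.6%. The second is compound 2 `CCN(CC)c1ccc(C(=O)Nc2ccc(Oc3ncnc4ccsc34)cc2)cc1`, which in this assay gives 38.3%. Compound 2 has the smaller of the two figures, but the gap to compound 1 lies within the usual scatter of this kind of measurement, so the two compounds cannot be told apart on the numbers at hand.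

The next compound is compound 3 `CN(C)c1ccc(C(=O)Nc2ccc(Oc3ncnc4ccsc34)cc2)cc1`, which has not yet been measured. It differs from compound 2 in one place (dimethylamino in place of diethylamino on an aromatic carbon). Within the data shown here, no step between two measured compounds of this kind is available to set the size of the expected change, and the two values that exist lie within the scatter of each other, so nothing in the data points to a shift in either direction. The step from compound 2 to compound 3 is therefore expected to be small a number 0.3 percentage points lower from compound 2 to compound 3 (within the scatter), none beyond the scatter. Compound 3 is estimated to give 38% in this assay, with a range from 22% to 55%.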

Compound 3, a percentage reported as inhibition, at one concentration (the size of the read-out at that concentration, not a potency): 10.4%
The estimate for compound 3 lay 27.6 percentage points above the measured number; the whole stated range lies above it.
By their numbers in this assay, from the lowest: compound 3; then compounds 2 and 1 (each within the scatter of the next).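

Among these compounds, the exchange of diethylamino for dimethylamino, on an aromatic carbon para to a large group, gives a number 27.9 percentage points lower from compound 2 to compound 3 (beyond the scatter) in this assay, and this is the first step that stands clear of the scatter. The earlier values could not show that this position responds at all, whereas this single step shows that the read-out is sensitive to the group placed here, even though the change only takes the group from 5 heavy atoms to 3 heavy atoms, with no ring, no net charge and the same count of hydrogen-bond donors and acceptors on both sides. Nothing in the available data accounts for the size of this step.

As this is one step in one assay at one concentration, the compounds shown leave open whether the response follows the length of the chains on the nitrogen or is peculiar to this one pair. A longer chain such as dipropylamino, a ring amine such as pyrrolidine, or an unsubstituted amine at the same place would show whether the figure keeps rising with the larger groups or falls away again.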